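Aryl to hydroxypropyl: expected step for compound 3

The source may hold more compounds than are shown below. What is called first, only, known or untested is meant among the compounds shown, and "the series" means these compounds.

Within the data shown here, only two compounds have numbers so far. In a functional assay on HeLa cells (Homo sapiens) for inhibition, read by MTT assay, with a stated time of 4 days (on this read-out lower numbers stand for stronger inhibition and higher numbers for weaker inhibition), compound 1 (`COc1cc(NC(C)CCCNC(=O)NNC(=O)Nc2ccc(Cl)c(C(F)(F)F)c2)c2ncccc2c1`) gives 17000 nM and holds the lower of the two numbers. In this assay compound 2 (`COc1cc(NC(C)CCCNC(=O)NNC(=O)NCCCC(C)Nc2cc(OC)cc3cccnc23)c2ncccc2c1`) gives 67000 nM and the gap between the two lies beyond the scatter.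

Compound 3 (`COc1cc(NC(C)CCCNC(=O)NNC(=O)NCCCO)c2ncccc2c1`) has not yet been measured. It carries 3-hydroxypropyl in place of 4-chloro-3-(trifluoromethyl)phenyl on an amide-type nitrogen. Among the measured compounds shown here, no measured pair isolates this change, so the size of the step remains a judgement. For the measured compounds named here, compound 2 also lacks the 4-chloro-3-(trifluoromethyl)phenyl group, and its 67000 nM stands higher than the number for compound 1, which is the only guide available. A move toward a higher number and weaker inhibition is therefore expected, with the estimated size given by a 3.5-fold higher number from compound 1 to compound 3 (0.55 log units; beyond the scatter) in this assay as a working figure. In this assay compound 3 is expected at 60000 nM with an estimated range from 20000 nM to 150000 nM as the likely span.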

Compound 3, half-maximal inhibitory concentration: > 250000 nM
Compound 3 ended at the assay's limit; the forecaster's own chance of this, stated with the estimate: 30%; middle value at least 4.1-fold (0.61 log units) away from the limit.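

Among these compounds, on the amide-type nitrogen whose other neighbour is the carbonyl carbon, 3-hydroxypropyl in place of 4-chloro-3-(trifluoromethyl)phenyl gives, in this assay, an at least 14-fold higher number from compound 1 to compound 3 (1.16 log units; beyond the scatter), the first step that isolates a change at this position. Compound 3 stands at a limit of the assay and not at a number, so the step fixes only a minimum size: the limit of > 250000 nM in this assay, at which 1 of the 3 values shown sits.

In this pair, the 4-chloro-3-(trifluoromethyl)phenyl group cannot be exchanged for 3-hydroxypropyl without a large move toward weaker inhibition, a finding that rests on this single change at this single position.

The compounds shown do not separate the loss of the substituted aromatic ring from the entry of the terminal hydroxyl, and an unsubstituted phenyl, a cyclohexyl or a plain propyl chain on the same nitrogen would bear on that question. Also open, from the compounds shown here alone, is how this position responds to a chain ending in an amine or a carboxylic acid, or to a longer chain than 3-hydroxypropyl.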